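This account rests on a few compounds, and the source may have more. Where it says the series, first, only, none or still open, it means among the compounds named here.

Measured so far:
- compound 1, `CCCCNc1ccnc2cc(Cl)ccc12`: 5600 nM in a functional assay on MCF7 cells (Homo sapiens) for cytotoxicity, read by sulforhodamine B assay, with a stated time of 48 h, in the presence of a further agent that is not named here; on this read-out higher numbers stand for weaker inhibition of growth and lower numbers for stronger inhibition of growth
- compound 2, `CCCCNc1ccnc2cc(F)ccc12`: 1630 nM in this assay

Among the measured compounds shown here, compound 1 gives the highest of the two numbers in this assay; its only neighbour is compound 2, and the step of a 3.4-fold lower number from compound 1 to compound 2 (0.54 log units; beyond the scatter) is the sole measured change, a halogen exchange on the aromatic carbon that leaves the chain on the ring nitrogen untouched.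

Compound 3, `CN(C)CCNc1ccnc2cc(Cl)ccc12`, differs from compound 1 in a different place: dimethylamino in place of ethyl on a saturated chain carbon, two bonds along the chain from a nitrogen on an aromatic ring. For the measured compounds named here, no measured step touches this chain, so the halogen step of compound 2 says nothing about it, and there is no pairing elsewhere from which a direction could be read. The expectation for compound 3 therefore rests on compound 1 alone, which gives 5600 nM, with a range wide enough to cover a change in either direction beyond the scatter.

Going by the values given here, the expected step is a 1.2-fold lower number from compound 1 to compound 3 (0.09 log units; within the scatter), with no measured analogue to anchor it. Compound 3 is estimated at 4500 nM, with a range from 1500 nM to 13000 nM.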

Compound 3, concentration for 50% growth inhibition: 3320 nM
For compound 3 the middle estimate is 1.4-fold (0.13 log units) above the measured one, within the range that was stated.
By their numbers in this assay, from the lowest: compound 2; then compounds 3 and 1 (each within the scatter of the next).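

In this assay, the saturated chain carbon two bonds along the chain from a nitrogen on an aromatic ring now has its first measured change: dimethylamino in place of ethyl gives a 1.7-fold lower number from compound 1 to compound 3 (0.23 log units; within the scatter). This exchange adds one nitrogen and one hydrogen-bond acceptor by count, yet it does not separate the two compounds on this read-out, whereas the halogen exchange, a 3.4-fold lower number from compound 1 to compound 2 (0.54 log units; beyond the scatter), remains the only step shown that lies beyond the scatter. No supporting measurement bears on this result, so the data offer no account of it.

The compounds shown leave open whether dimethylamino at this chain carbon would give a comparable step with fluoro on the shared core, as compound 2 and compound 3 differ in two places and cannot be compared directly. They also leave open whether a different group at this chain carbon, such as a morpholine, a pyrrolidine, a carboxylic acid or a longer chain ending in dimethylamino, would produce a step beyond the scatter.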